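Extending the chain substituent from methyl toward propyl

This account rests on a few compounds, and the source may have more. Where it says the series, first, only, none or still open, it means among the compounds named here.

Measured so far:
compound 1, `c1ccc2nc(COc3ccc(CC4CCCC4Cc4nnn[nH]4)cc3)ccc2c1` — 10 mg/kg
compound 2, `CC(CCc1nnn[nH]1)Cc1ccc(OCc2ccc3ccccc3n2)cc1` — 2.5 mg/kg

Of the compounds shown here, two have been measured in a functional assay on the whole organism with Cavia porcellus as the target; on this read-out lower numbers stand for an effect already at smaller amounts and higher numbers for an effect only at larger amounts of compound. Compound 2 gives 2.5 mg/kg, the lowest of the two numbers; compound 1 gives 10 mg/kg, a higher number that lies beyond the usual scatter. Compound 2 is therefore the starting point for the next compound, compound 3, `CCCC(CCc1nnn[nH]1)Cc1ccc(OCc2ccc3ccccc3n2)cc1`, which has not yet been measured in this assay.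

The difference between the two is ethyl in place of hydrogen on a saturated chain carbon, three bonds along the chain from an aromatic carbon.

For the measured compounds named here, no step between measured compounds carries this change, so there is nothing to read its size from. In this assay the expected step is estimated as a 1.4-fold higher number from compound 2 to compound 3 (0.15 log units; within the scatter), which would be only a slight shift toward a higher number. Compound 3 is thus expected to give about 3.5 mg/kg in this assay, within the range 1.3 mg/kg to 9 mg/kg.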

Compound 3, dose for half-maximal effect: 7.2 mg/kg
Beside the measured number, compound 3's estimate is 2.1-fold (0.31 log units) below it; the measured number falls inside the stated range.
By their numbers in this assay, from the lowest: compound 2; then compounds 3 and 1 (each within the scatter of the next).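

In this assay, for the compounds shown here, the step at this saturated chain carbon, three bonds along the chain from an aromatic carbon, is a 2.9-fold higher number from compound 2 to compound 3 (0.46 log units; beyond the scatter) and gives the first size for any change at this place. Read one bond further out, the same difference is methyl to propyl, so the longer chain here goes with a modest move toward a higher number, beyond the scatter. Nothing available explains this shift.

The compounds shown leave open whether a still longer chain, such as butyl, on this carbon would move the number further in the same direction. They also leave open how a group of another kind, such as an amine or a carboxylic acid, would behave at this position.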